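Swapping acetamido for sulfamoyl on the anilino ring

The source may report more compounds than this note shows. Statements on the series, on what has been measured and on what is new or still open speak of the compounds shown alone.

Measured so far:
Compound 1, `NS(=O)(=O)c1cccc(Nc2nccc(-c3cccnc3)n2)c1`, gives 200 nM.
Compound 2, `COc1cccc(Nc2nccc(-c3ccncc3)n2)c1`, gives 400 nM.
Compound 3, `CC(=O)Nc1cccc(Nc2nccc(-c3ccncc3)n2)c1`, gives 2700 nM.

These three compounds share a core and differ in the group on the anilino ring, and in one case in the pyridine. In a functional assay for inhibition, with Homo sapiens as the target (on this read-out higher numbers stand for weaker inhibition and lower numbers for stronger inhibition), compound 3 gives the highest of the three numbers, that is the weakest inhibition; its nearest neighbour is compound 2, and compound 1 lies furthest from it. Going by the values given here, the one measured step that reaches compound 3 is a 6.8-fold higher number from compound 2 to compound 3 (0.83 log units; beyond the scatter).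

The next compound, compound 4, `NS(=O)(=O)c1cccc(Nc2nccc(-c3ccncc3)n2)c1`, is not yet measured. Relative to compound 3 the change is sulfamoyl in place of acetamido on an aromatic carbon: the acetamido leaves and the sulfamoyl enters, on an aromatic carbon of a six-membered aromatic ring of carbon only, meta to a large group. Among the compounds with values here, no measured step shows exactly this exchange. What bears on it is that the acetamido gave the weakest inhibition in the series, and that compound 1, which carries the same sulfamoyl group, sits at the strong end with 200 nM. On that basis a step back toward stronger inhibition is expected, roughly undoing the loss seen on the way to compound 3, so compound 4 is estimated at 300 nM with a range from 100 nM to 1000 nM. The expected step is a 9.0-fold lower number from compound 3 to compound 4 (0.95 log units; beyond the scatter).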

Compound 4, half-maximal inhibitory concentration: 500 nM
Compound 4: middle estimate off by 1.7-fold (0.22 log units), on the low side, and the stated range covers the measured number.
By their numbers in this assay, from the lowest: compounds 1, 2 and 4 (each within the scatter of the next, the first and the last beyond it); then compound 3.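

In this assay, replacing acetamido with sulfamoyl on this aromatic carbon gives a 5.4-fold lower number from compound 3 to compound 4 (0.73 log units; beyond the scatter) and so shows that the weak inhibition of compound 3 is tied to the acetamido group, at least against this one replacement. Sulfamoyl and methoxy cannot be told apart at this carbon when the pyridin-4-yl is kept, since a 1.3-fold higher number from compound 2 to compound 4 (0.10 log units; within the scatter) is a step that stays inside the usual scatter of the measurement. Going by these compounds alone, the same sulfamoyl group also allows the first clean look at the pyridine, where pyridin-4-yl in place of pyridin-3-yl gives a 2.5-fold higher number from compound 1 to compound 4 (0.40 log units; beyond the scatter) and so a modest loss of inhibition.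

Nothing shown here gives a reason for these differences. As far as these compounds go, whether an amine or a carboxylic acid on this carbon would track with sulfamoyl and methoxy or with acetamido stays open, as does whether the pyridine change has the same effect with methoxy or acetamido on the ring.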